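The compounds below may be only part of what the source reports. "The series", "measured", "known", "first", "only" and "open" are said of these compounds alone.

Three compounds have been measured in an assay for displacement of a labelled ligand from Sigma non-opioid intracellular receptor 1 (Cavia porcellus), read by scintillation counting, with a stated time of 180 min; a higher number here means a weaker inhibitor, a lower number a stronger inhibitor:

Compound 1 `OC1CN(CCCOc2ccccc2)CCc2cc(OCc3ccccc3)ccc21`: 193 nM
Compound 2 `CC1(C)COC(CCCN2CCc3cc(OCc4ccccc4)ccc3C(O)C2)(c2ccc(C(C)(C)C)cc2)OC1`: > 1000 nM
Compound 3 `OC1CN([C@H]2CC[C@@H](c3ccccc3)CC2)CCc2cc(OCc3ccccc3)ccc21`: 10 nM

Of the two numbers obtained in this assay, compound 1 has the higher one. The nearest neighbour is compound 3 at 10 nM, and the gap between the two lies beyond the scatter of repeated measurements. The value of compound 2 is a limit of this assay and not a number; it sits at the limit of > 1000 nM in this assay, at which 1 of the 3 values shown sits. Within the data shown here, no two of the measured compounds differ from each other in a single place, so no measured step is at hand from which the effect of a single change could be read.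

Compound 4 `O=C(CCCN1CCc2cc(OCc3ccccc3)ccc2C(O)C1)c1ccc(F)cc1` has not yet been measured. It differs from compound 1 in one place: (4-fluorophenyl)carbonyl in place of phenoxy on a saturated chain carbon, three bonds along the chain from an amine nitrogen in a ring. Among the measured compounds shown here, with no measured step to lean on, what follows is an expectation only. The step of a 3.9-fold lower number from compound 1 to compound 4 (0.59 log units; beyond the scatter) is expected to run downward, toward a stronger inhibitor, by more than the scatter. Compound 4 is accordingly expected to give about 50 nM in this assay, within a range from 10 nM to 250 nM.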

Compound 4, inhibition constant: 293 nM
Estimate against measurement, compound 4: 5.9-fold (0.77 log units) below; the whole stated range lies below it.
By their numbers in this assay, from the lowest: compound 3; then compounds 1 and 4 (each within the scatter of the next). At a limit, above all of these: compound 2.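

The step of a 1.5-fold higher number from compound 1 to compound 4 (0.18 log units; within the scatter) in this assay is the first change in a single place among the compounds shown, with (4-fluorophenyl)carbonyl in place of phenoxy on a saturated chain carbon, three bonds along the chain from an amine nitrogen in a ring. At this position, the read-out does not tell the two groups apart, even though the entering group has more heavy atoms, adds a double bond outside aromatic rings and brings in fluorine, while both groups hold one six-membered aromatic ring and one hydrogen-bond acceptor. Nothing at hand gives a reason for this outcome.

Still open, on these data alone, is whether the same holds for a plain phenylcarbonyl without the fluorine, for a hydroxyl in place of the carbonyl, or for an amide or a sulfonyl at the same place. Also open, as far as these compounds go, is whether either group would behave the same way on a shorter or a longer chain, since this single step speaks only for the chain that compound 1 and compound 4 share.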